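The compounds below may be only part of what the source reports. "The series", "measured", "known", "first", "only" and "open" are said of these compounds alone.

Compound 2 `CC[C@H](C)[C@H](N)CN(C(=O)[C@@H]1C[C@H]1c1c(F)cccc1F)c1ccc(-c2ccccc2)cc1` gives 11000 nM in a functional assay for agonist activity at G protein-coupled receptor 88 (Homo sapiens), read by HTRF and cAMP accumulation (a higher number here means that more compound is needed for the effect, a lower number that less compound is needed), the higher of the two numbers recorded, while compound 1 `CC[C@H](C)[C@H](N)CN(C(=O)[C@@H]1C[C@H]1c1cccc(C)c1)c1ccc(-c2ccccc2)cc1` gives 1200 nM. Within the data shown here, the single measured step, a 9.2-fold higher number from compound 1 to compound 2 (0.96 log units; beyond the scatter), shows that the aromatic group on the saturated ring carbon shifts the read-out well beyond the scatter. Compound 3 `CC[C@H](C)[C@H](N)CN(C(=O)[C@@H]1C[C@H]1c1cccnc1)c1ccc(-c2ccccc2)cc1` differs from compound 2 by pyridin-3-yl in place of 2,6-difluorophenyl on a saturated ring carbon. Among the measured compounds shown here, no measured step exchanges this group for a pyridine, so the expectation leans on that one step alone and stays wide. Compound 3 is therefore expected to give 2500 nM, within 600 nM to 10000 nM, an estimated move of a 4.4-fold lower number from compound 2 to compound 3 (0.64 log units; beyond the scatter).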

Compound 3, half-maximal effective concentration: 1500 nM
Estimate against measurement, compound 3: 1.7-fold (0.22 log units) above; low and high end bracket the measured number.
By their numbers in this assay, from the lowest: compounds 1 and 3 (each within the scatter of the next); then compound 2.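

In this assay, pyridin-3-yl on the saturated ring carbon gives a 7.3-fold lower number from compound 2 to compound 3 (0.87 log units; beyond the scatter) and so recovers the loss seen with 2,6-difluorophenyl, showing that the high number of compound 2 is not common to every aromatic group at this position. With a 1.3-fold higher number from compound 1 to compound 3 (0.10 log units; within the scatter) as the other step, pyridin-3-yl and 3-methylphenyl cannot be told apart here. Nothing available explains the difference between these groups. Going by these compounds, it remains open whether a plain phenyl or a fluorophenyl carrying a single fluorine would sit nearer compound 1 or compound 2, and how a cyclohexyl group would compare.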